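Two Fluorines Move on the Aryl Group of Compound 2

A few compounds are considered here, and "the series" means these few. Any claim that something is new, unique, unknown or untested is made for them only; others in the source may bear on it.

Compound 1 `Nc1scc(CN2CCN(c3ccc(Cl)c(C(F)(F)F)c3)CC2)c1C(=O)c1ccc(Cl)cc1` carries a 4-chloro-3-(trifluoromethyl)phenyl on an amine nitrogen in a ring; in a functional assay on CHO cells with adenosine receptor A1 (Homo sapiens) as the target, read by cAMP accumulation and immunoassay, with a stated time of 6 min, tested at 10 uM (on this read-out higher numbers stand for a weaker effect at the one concentration tested and lower numbers for a stronger effect), compound 1 gives -60%. Compound 2 `Nc1scc(CN2CCN(c3ccc(F)cc3F)CC2)c1C(=O)c1ccc(Cl)cc1`, with 2,4-difluorophenyl in that place, gives -82% in this assay, the lowest of the two numbers recorded; the step of a number 22 percentage points lower from compound 1 to compound 2 (beyond the scatter) was modest. Compound 3 `Nc1scc(CN2CCN(c3cccc(F)c3F)CC2)c1C(=O)c1ccc(Cl)cc1` differs from compound 2 only in 2,3-difluorophenyl in place of 2,4-difluorophenyl on an amine nitrogen in a ring. Within the data shown here, no measured step covers this change, and the one recorded step concerns a different aryl swap. Compound 3 is expected to shift by a number 7 percentage points higher from compound 2 to compound 3 (within the scatter), a step within the scatter. In this assay compound 3 is estimated at -75%, between -95% and -50%.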

Compound 3, a percentage reported as activity, at one concentration (the size of the read-out at that concentration, not a potency): -79%
Beside the measured number, compound 3's estimate is 4 percentage points above it, and the stated range covers the measured number.
By their numbers in this assay, from the lowest: compounds 2 and 3 (each within the scatter of the next); then compound 1.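

In this assay, 2,3-difluorophenyl in place of 2,4-difluorophenyl gives a number 3 percentage points higher from compound 2 to compound 3 (within the scatter), so at this position the two arrangements of the fluorines cannot be told apart. The difference from the 4-chloro-3-(trifluoromethyl)phenyl group also holds for the new arrangement, with a number 19 percentage points lower from compound 1 to compound 3 (beyond the scatter), so it is not confined to the 2,4-difluorophenyl of compound 2. Nothing available explains these results. On these data alone, whether a phenyl carrying a single fluorine or a methoxy group would read like the two difluorophenyl compounds remains open.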